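A few compounds are considered here, and "the series" means these few. Any claim that something is new, unique, unknown or untested is made for them only; others in the source may bear on it.

Compound 3 `C=CCn1c(=O)/c(=C\c2cccc(Br)c2)[nH]c(=O)/c1=C\c1ccccc1OC` is a symmetric-looking core carrying two aryl groups on double-bonded chain carbons. In a functional assay on BGC-823 cells (Homo sapiens) for cytotoxicity, read by CCK-8 assay, with a stated time of 72 h (a lower number here means a stronger inhibitor, a higher number a weaker inhibitor), compound 3 gives 5900 nM, the highest of the two numbers recorded, and thus the weakest inhibitor among the compounds with a number. Among the compounds with values here, its closest neighbour is compound 2 `C=CCn1c(=O)/c(=C\c2cc(F)ccc2C)[nH]c(=O)/c1=C\c1ccccc1OC`, for which 1600 nM was found; the only single-point step recorded, a 3.7-fold higher number from compound 2 to compound 3 (0.57 log units; beyond the scatter), describes exactly that swap. Compound 1 `COc1ccccc1/C=c1/[nH]c(=O)/c(=C\c2ccccc2OC)[nH]c1=O` carries two 2-methoxyphenyl groups and is reported in this assay as "not active" (no number reported), without a number.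

Compound 4 `C=CCn1c(=O)/c(=C\c2ccccc2OC)[nH]c(=O)/c1=C\c1ccccc1OC` arises from compound 3 through (2-methoxyphenyl in place of 3-bromophenyl on a double-bonded chain carbon bound to an aromatic carbon). Within the data shown here, no measured step covers this exchange, so the direction is taken from two indirect hints: compound 3 already sits weaker than compound 2 after one aryl change, and compound 4 ends up with the same pair of 2-methoxyphenyl groups as compound 1, which showed "not active" (no number reported). Compound 4 keeps the rest of the core of compound 3, so some activity is expected, but weaker than compound 3; the expected step is a 2.4-fold higher number from compound 3 to compound 4 (0.38 log units; beyond the scatter). The estimate for compound 4 is therefore 14000 nM, within a range of 4000 nM to 50000 nM, with a real chance that only a limit is reported.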

Compound 4, half-maximal inhibitory concentration: 13400 nM
Estimate against measurement, compound 4: 1.0-fold (0.02 log units) above; the measured number falls inside the stated range.
By their numbers in this assay, from the lowest: compound 2; then compound 3; then compound 4.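

Placing 2-methoxyphenyl on this double-bonded chain carbon gives a 2.3-fold higher number from compound 3 to compound 4 (0.36 log units; beyond the scatter) in this assay, and the same group set against 5-fluoro-2-methylphenyl gives an 8.4-fold higher number from compound 2 to compound 4 (0.92 log units; beyond the scatter). With three different aryl groups now read at this one place, and the other 2-methoxyphenyl group held fixed, the order from the lowest number upward is 5-fluoro-2-methylphenyl, 3-bromophenyl, 2-methoxyphenyl. Compound 4 also shows that the pair of 2-methoxyphenyl groups can still give a number when the allyl chain is present on the core, whereas compound 1, which has the same pair without that chain, gives "not active" (no number reported).

No measurement among these results explains this order. The three groups differ in more than one feature at once, and the compounds shown leave open which feature matters and whether the order would hold with a different group at the other aryl place. A plain phenyl, or a phenyl carrying an amine or a carboxylic acid, also has no place in this order yet.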